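Butoxy for butylamino: what the known steps can say

The source may report more compounds than this note shows. Statements on the series, on what has been measured and on what is new or still open speak of the compounds shown alone.

Compound 1 `CCCCNc1nc(N)nc2cccnc12` is the reference point here. Among the measured compounds shown here, in an assay on tissue (PBMC cells) for agonist activity at Toll-like receptor 8 (Homo sapiens), with a stated time of 24 h (a lower number here means that less compound is needed, a higher number that more compound is needed for the effect), compound 1 gives 1900 nM, the second highest of the three numbers measured so far. Compound 2 `CCCC(C)Nc1nc(N)nc2cccnc12` gives 3100 nM, and compound 3 `CCC[C@@H](CO)Nc1nc(N)nc2cccnc12` gives 430 nM. The step of a 1.6-fold higher number from compound 1 to compound 2 (0.21 log units; within the scatter) stays within the scatter, whereas a 4.4-fold lower number from compound 1 to compound 3 (0.65 log units; beyond the scatter) and a 7.2-fold lower number from compound 2 to compound 3 (0.86 log units; beyond the scatter) are modest steps beyond it, both reached by putting a hydroxymethyl onto the chain.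

The unmeasured compound 4 `CCCCOc1nc(N)nc2cccnc12` differs from compound 1 in one place: butoxy in place of butylamino on an aromatic carbon. For the measured compounds named here, none of the measured steps touches this spot; each of them alters a saturated chain carbon and keeps the nitrogen on the aromatic ring, so no step shows directly what its exchange for oxygen does. Going by the values given here, the only indirect hint is that the one change that clearly helped, a 4.4-fold lower number from compound 1 to compound 3 (0.65 log units; beyond the scatter), came with an added hydrogen-bond donor, while compound 4 instead loses the hydrogen-bond donor of the butylamino group. On that thin basis a step toward a higher number is expected, a 3.2-fold higher number from compound 1 to compound 4 (0.50 log units; beyond the scatter), of a size comparable to the measured steps but with wide uncertainty. Compound 4 is therefore estimated at 6000 nM, with a range from 1500 nM to 25000 nM.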

Compound 4, half-maximal effective concentration: > 50000 nM
Compound 4: no number, only a limit (the forecaster's own chance of this, stated with the estimate: 20%); at least 8.3-fold (0.92 log units) between middle value and limit.
By their numbers in this assay, from the lowest: compound 3; then compounds 1 and 2 (each within the scatter of the next). At a limit, above all of these: compound 4.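

Compound 4 has no number in this assay, only a limit: the limit of > 50000 nM in this assay, at which 1 of the 4 values shown sits.

Even as a limit, this amounts to an at least 26-fold higher number from compound 1 to compound 4 (1.42 log units; beyond the scatter), so the change on this aromatic carbon outweighs anything seen so far on the chain, where the largest listed step is a 7.2-fold lower number from compound 2 to compound 3 (0.86 log units; beyond the scatter). The earlier compounds shown here all kept the nitrogen and varied only the chain, whereas this result shows that the atom joining the chain to the shared core is a very sensitive spot in this small set: the carbon chain stays the same, and butoxy in place of butylamino is enough to take the compound out of the measurable range.

The compounds shown cannot separate the loss of the hydrogen-bond donor from the presence of oxygen itself, a question that a butyl(methyl)amino group, which keeps the nitrogen but carries no hydrogen on it, would address. They also leave open whether the hydroxymethyl that lowered the number on the butylamino chain would restore any activity on a butoxy chain.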